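Removing the acyl group from compound 1

This account rests on a few compounds, and the source may have more. Where it says the series, first, only, none or still open, it means among the compounds named here.

Compound 1 `CCCC(=O)n1nc(C)c(-c2ccc(Cl)c(Cl)c2)c1N` stands in an assay on Sf9 cells for inhibition of mitogen-activated protein kinase kinase kinase 14 (Homo sapiens), read by ADP-Glo, with a stated time of 60 min (on this read-out lower numbers stand for stronger inhibition and higher numbers for weaker inhibition), only at a limit, not a number: compound 1 gives > 100000 nM (the limit of > 100000 nM in this assay, at which 1 of the 3 values shown sits). Its measured neighbours keep the carbonyl. Compound 2 `Cc1nn(C(=O)C2CCCCC2)c(N)c1-c1ccc(Cl)c(Cl)c1` gives 3300 nM and compound 3 `Cc1nn(C(=O)c2ccccc2)c(N)c1-c1ccc(Cl)c(Cl)c1` gives 23000 nM. The steps of an at least 30-fold lower number from compound 1 to compound 2 (1.48 log units; beyond the scatter) and an at least 4.3-fold lower number from compound 1 to compound 3 (0.63 log units; beyond the scatter) both run from the propyl limit to a number, and a 7.0-fold higher number from compound 2 to compound 3 (0.84 log units; beyond the scatter) separates the two cyclic groups. Compound 4 `Cc1nn(C)c(N)c1-c1ccc(Cl)c(Cl)c1` differs from compound 1 by methyl in place of propylcarbonyl on an aromatic nitrogen. For the measured compounds named here, no measured step removes the carbonyl, so these steps bear only indirectly; all three measured compounds carry an acyl group, and the smallest of them, compound 1, sits at the limit. Compound 4 is therefore expected to remain near that limit, the step of a number no higher from compound 1 to compound 4 (the limit leaves the size open) expected within the scatter, with an estimate of 100000 nM (from 30000 nM to 300000 nM).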

Compound 4, half-maximal inhibitory concentration: > 100000 nM
Compound 4: a limit, no number (the forecaster's own chance of this, stated with the estimate: 60%); the middle value lies on the limit itself.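

For the compounds shown here, compound 1 and compound 4 both give a limit rather than a number, so no step between them can be read. The compounds shown leave open whether any group without a carbonyl on that aromatic nitrogen gives a number.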